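The source may hold more compounds than are shown below. What is called first, only, known or untested is meant among the compounds shown, and "the series" means these compounds.

Series notes. Compound 1 `Nc1scc(CN2CCN(c3ccccc3C(F)(F)F)CC2)c1C(=O)c1ccc(Cl)cc1` and compound 2 `Nc1scc(CN2CCN(c3c(F)cccc3F)CC2)c1C(=O)c1ccc(Cl)cc1` share one core and differ only in the group carried on an amine nitrogen in a ring. In an assay on CHO cells for displacement of a labelled ligand from adenosine receptor A1 (Homo sapiens), read by scintillation counting, with a stated time of 120 min, tested at 10 uM (on this read-out higher numbers stand for more inhibition at the one concentration tested (going by the name of the read-out) and lower numbers for less inhibition), compound 1 gives 0%, and compound 2 gives 1%. The step of a number 1 percentage points higher from compound 1 to compound 2 (within the scatter) is within the scatter, so the two numbers cannot be told apart; compound 2 stands at a number indistinguishable from that of compound 1, both close to the bottom of the scale.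

Compound 3 `Nc1scc(CN2CCN(c3cccc(Cl)c3)CC2)c1C(=O)c1ccc(Cl)cc1` is the next member. Its change from compound 2 is 3-chlorophenyl in place of 2,6-difluorophenyl on an amine nitrogen in a ring, again an exchange of the group on an amine nitrogen in a ring. Among the compounds with values here, the only measured step bearing on this place, a number 1 percentage points higher from compound 1 to compound 2 (within the scatter), moved nothing beyond the scatter when one such group replaced another. Within the data shown here, no measured compound carries 3-chlorophenyl at this place, so there is nothing to show that this exchange would behave differently. The expected step of a number 1 percentage points higher from compound 2 to compound 3 (within the scatter) is therefore none beyond the scatter. Compound 3 is estimated at 2%, with a range from -8% to 14%.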

Compound 3, a percentage reported as inhibition, at one concentration (the size of the read-out at that concentration, not a potency): 0%
Compound 3: middle estimate off by 2 percentage points, on the high side; low and high end bracket the measured number.
By their numbers in this assay, from the lowest: compounds 1, 3 and 2 (each within the scatter of the next).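

In this assay, 3-chlorophenyl in place of 2,6-difluorophenyl on an amine nitrogen in a ring gives a number 1 percentage points lower from compound 2 to compound 3 (within the scatter), and 3-chlorophenyl in place of 2-(trifluoromethyl)phenyl at the same place gives no change at the digits printed from compound 1 to compound 3 (within the scatter). The earlier compounds shown here offered a single exchange at this place; there are now three substituted phenyl groups, carrying trifluoromethyl, fluorine or chlorine, and no two of them can be told apart, so within these compounds the identity of the substituent on this phenyl ring has no readable effect on the number. Nothing available here accounts for this flat result or shows what limits the read-out across the three compounds.

Still open, going by these compounds, is whether a group of another kind on this nitrogen, such as a pyridine ring, a benzyl group, an acyl group or a longer chain ending in a carboxylic acid, would separate from these three numbers. On these data alone, all three compounds also share the rest of the core, so the contribution of its free amine and its aryl ketone remains open as well.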